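This account rests on a few compounds, and the source may have more. Where it says the series, first, only, none or still open, it means among the compounds named here.

Measured so far:
compound 1 `CC1=C(/C=C/C(=O)/C=C/c2cccc(F)c2)C(C)(C)CCC1O` — 4400 nM
compound 2 `CC1=C(/C=C/C(=O)/C=C/c2ccc(F)cc2)C(C)(C)CCC1O` — 3900 nM

Both compounds were tested in a functional assay on LNCaP cells (Homo sapiens) for cytotoxicity, read by MTT assay, with a stated time of 72 h; a lower number here means a stronger inhibitor, a higher number a weaker inhibitor. Compound 1 gives 4400 nM and compound 2 gives 3900 nM; the two numbers lie within the scatter of each other, so neither compound can be set apart from the other. Among the compounds with values here, the only measured step, a 1.1-fold lower number from compound 1 to compound 2 (0.05 log units; within the scatter), moves a fluorine from one position of the ring to another and does not change the number beyond the scatter.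

Compound 3 `CC1=C(/C=C/C(=O)/C=C/c2cccc(C)c2)C(C)(C)CCC1O` is not yet measured. It differs from compound 2 in one place: 3-methylphenyl in place of 4-fluorophenyl on a double-bonded chain carbon bound to a double-bonded chain carbon. Within the data shown here, no measured step shows what a methyl group does in place of a fluorine on this ring, so the expectation rests only on the small effect seen so far. The estimate is that the step of a 1.0-fold higher number from compound 2 to compound 3 (0.01 log units; within the scatter) stays within the scatter. Compound 3 is therefore expected to give about 4000 nM, with a range from 2000 nM to 8000 nM.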

Compound 3, half-maximal inhibitory concentration: 4100 nM
Compound 3: middle estimate off by 1.0-fold (0.01 log units), on the low side, and the stated range covers the measured number.
By their numbers in this assay, from the lowest: compounds 2, 3 and 1 (each within the scatter of the next).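

In this assay, within the data shown here, the ring carries something other than fluorine for the first time, and the cleanest comparison is methyl in place of fluoro on an aromatic carbon, where a 1.1-fold lower number from compound 1 to compound 3 (0.03 log units; within the scatter) stays within the scatter. The wider change to 3-methylphenyl from 4-fluorophenyl, which alters both the group and where it sits, gives a 1.1-fold higher number from compound 2 to compound 3 (0.02 log units; within the scatter) and is also within the scatter. So on this ring, a methyl group and a fluoro group cannot be told apart by these numbers, and nothing further is available to explain the result.

Still open, going by these compounds, is whether an amine or a carboxylic acid on the ring would move the number beyond the scatter. Also open, on these data alone, is whether changing the hydroxyl group on the other side of the shared core would do so.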